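A few compounds are considered here, and "the series" means these few. Any claim that something is new, unique, unknown or untested is made for them only; others in the source may bear on it.

Compound 1 `COc1ccc(/C=C\c2cc(OC)c(OC)c(OC)c2)cc1OCc1ccc(CN2CC[C@H](O)C2)cc1` gives 7200 nM
Compound 2 `COc1ccc(/C=C\c2cc(OC)c(OC)c(OC)c2)cc1OCc1ccc(CNCCN(C)C)cc1` gives 1400 nM

Within the data shown here, in a functional assay on MC-38 cells (Mus musculus) for antiproliferative activity, read by CCK-8 assay, with a stated time of 48 h (on this read-out lower numbers stand for stronger inhibition and higher numbers for weaker inhibition), compound 2 gives 1400 nM as the lower of the two numbers so far. Compound 3 `COc1ccc(/C=C\c2cc(OC)c(OC)c(OC)c2)cc1OCc1ccc(CN2CCCCC2C(=O)NCCN)cc1` is changed at the same place as the step between the measured pair, on a saturated chain carbon bound to an aromatic carbon: 2-((2-aminoethyl)carbamoyl)piperidin-1-yl in place of (2-(dimethylamino)ethyl)amino on a saturated chain carbon bound to an aromatic carbon. Among the measured compounds shown here, only one measured step bears on this place: a 5.1-fold lower number from compound 1 to compound 2 (0.71 log units; beyond the scatter). For the measured compounds named here, that single modest step shows that a change here can move the number beyond the scatter, but no measured compound carries 2-((2-aminoethyl)carbamoyl)piperidin-1-yl, so its direction cannot be carried over with confidence. A step of no greater size is expected, leaning toward a higher number: a 1.8-fold higher number from compound 2 to compound 3 (0.25 log units; within the scatter). In this assay the expected value for compound 3 is 2500 nM with an estimated range from 600 nM to 9000 nM.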

Compound 3, half-maximal inhibitory concentration: > 10000 nM
Compound 3: only a limit was reported; the forecaster's own chance of this, stated with the estimate: 5%; at least 4.0-fold (0.60 log units) between middle value and limit.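

In this assay compound 3 gives > 10000 nM, which is a limit of the assay and not a number. The step of an at least 7.1-fold higher number from compound 2 to compound 3 (0.85 log units; beyond the scatter) shows that a change on a saturated chain carbon bound to an aromatic carbon can also raise the number, so the advantage of the (2-(dimethylamino)ethyl)amino group does not carry over to the larger 2-((2-aminoethyl)carbamoyl)piperidin-1-yl group. The remaining step reads an at least 1.3-fold higher number from compound 1 to compound 3 (0.14 log units; that floor lies within the scatter), so no order can be set between these two compounds.

The compounds shown leave open whether the rise follows the six-membered ring or the carbamoyl chain on it. A plain piperidin-1-yl group and an open-chain amide carrying the same 2-aminoethyl end would separate these two parts.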